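Dropping one methoxy group from the triazole-linked aryl of compound 1

The compounds below may be only part of what the source reports. "The series", "measured", "known", "first", "only" and "open" are said of these compounds alone.

Compound 1 `COc1ccc(OC)c(-c2cn(-c3ccc(O)c(C(=O)Nc4cccc(C(F)(F)F)c4)c3)nn2)c1` gives 12900 nM in a functional assay on HCT-116 cells (Homo sapiens) for inhibition, read by MTT assay, with a stated time of 2 days; a lower number here means a stronger inhibitor of growth, a higher number a weaker inhibitor of growth.
Compound 2 `COC(=O)c1cc(-n2cc(-c3cc(O)ccc3O)nn2)ccc1O` gives a limit of the assay, > 100000 nM.

Going by the values given here, compound 1 holds the only measured number in this assay; the reading for compound 2 is a limit of the assay, so the two cannot be ordered with confidence, and the limit of > 100000 nM in this assay, at which 1 of the 2 values shown sits, is all that can be said of compound 2. Compound 3 `COc1ccccc1-c1cn(-c2ccc(O)c(C(=O)Nc3cccc(C(F)(F)F)c3)c2)nn1` differs from compound 1 by hydrogen in place of methoxy on an aromatic carbon. Among the compounds with values here, with no measured step of this kind to lean on, the estimate for compound 3 is that it remains close to compound 1, a step of a 1.2-fold higher number from compound 1 to compound 3 (0.07 log units; within the scatter) that stays within the usual scatter. Compound 3 is expected to give about 15000 nM, between 5000 nM and 50000 nM.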

Compound 3, concentration for 50% growth inhibition: 7920 nM
Estimate against measurement, compound 3: 1.9-fold (0.28 log units) above; the measured number falls inside the stated range.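

Going from 2,5-dimethoxyphenyl to 2-methoxyphenyl gives a 1.6-fold lower number from compound 1 to compound 3 (0.21 log units; within the scatter) in this assay. Going by these compounds alone, this is the first measured step at this position, and it shows that hydrogen can stand in place of this methoxy group with the reading staying within the usual scatter. Nothing shown here bears on the reason for this step.

From the compounds shown here alone, whether an amine or a carboxylic acid at this position would give a step beyond the scatter remains open. So does the effect of replacing the remaining methoxy group with hydrogen.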